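Aryl variation on the shared core: methoxy to methyl

The source may report more compounds than this note shows. Statements on the series, on what has been measured and on what is new or still open speak of the compounds shown alone.

Compound 3 `COc1ccc(-n2cc(CN3C(=O)C[C@@H]4CC[C@@]3(C)C4(C)C)nn2)cc1` gives the highest number of the three compounds measured in a functional assay on OVCAR-3 cells (Homo sapiens) for inhibition, read by MTT assay, with a stated time of 24 h (a lower number here means a stronger inhibitor, a higher number a weaker inhibitor), at 250 nM. Its nearest neighbour is compound 2 `Cc1ccccc1-n1cc(CN2C(=O)C[C@@H]3CC[C@@]2(C)C3(C)C)nn1`, with 150 nM; the step of a 1.7-fold higher number from compound 2 to compound 3 (0.22 log units; within the scatter) lies within the scatter. The furthest is compound 1 `CC1(C)[C@H]2CC[C@]1(C)N(Cc1cn(-c3cccc(Cl)c3)nn1)C(=O)C2`, with 50 nM; the step of a 5.0-fold higher number from compound 1 to compound 3 (0.70 log units; beyond the scatter) lies beyond it, as does a 3.0-fold higher number from compound 1 to compound 2 (0.48 log units; beyond the scatter).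

Compound 4 `Cc1ccc(-n2cc(CN3C(=O)C[C@@H]4CC[C@@]3(C)C4(C)C)nn2)cc1` differs from compound 3 by methyl in place of methoxy on an aromatic carbon, on an aromatic carbon of a six-membered aromatic ring of carbon only. Going by the values given here, no measured step exchanges a methoxy for a methyl at the same place. Among the compounds with values here, the only step that pairs a methyl-bearing aryl with the methoxy-bearing aryl is a 1.7-fold higher number from compound 2 to compound 3 (0.22 log units; within the scatter), and it stays within the scatter, while the two steps beyond the scatter both start from the chloro-bearing compound 1 and do not touch this change. In this assay compound 4 is therefore expected to show no step beyond the scatter, the expected step being a 1.3-fold lower number from compound 3 to compound 4 (0.10 log units; within the scatter). Compound 4 is estimated at 200 nM, within the range 90 nM to 450 nM.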

Compound 4, half-maximal inhibitory concentration: 40 nM
Beside the measured number, compound 4's estimate is 5.0-fold (0.70 log units) above it; the measured number lies below the stated range.
By their numbers in this assay, from the lowest: compounds 4 and 1 (each within the scatter of the next); then compounds 2 and 3 (each within the scatter of the next).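

At this place, para to a large group, methyl in place of methoxy matters in this assay, with a 6.3-fold lower number from compound 3 to compound 4 (0.80 log units; beyond the scatter). The location of the methyl also matters, with a 3.8-fold lower number from compound 2 to compound 4 (0.57 log units; beyond the scatter), so the step within the scatter between the 2-methylphenyl and 4-methoxyphenyl compounds gave no guide to this exchange. The 4-methylphenyl and 3-chlorophenyl compounds cannot be separated, with a 1.3-fold lower number from compound 1 to compound 4 (0.10 log units; within the scatter), so two differently substituted aryl groups now share the low end of this small set.

Nothing available accounts for the gap between the methyl and methoxy compounds. Going by these compounds, it remains open whether an ethyl, a hydroxyl or an amine at this same place would read like methyl or like methoxy.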